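The source may report more compounds than this note shows. Statements on the series, on what has been measured and on what is new or still open speak of the compounds shown alone.

Measured in an ADME assay on Akata cells (Homo sapiens) for cytotoxicity, with a stated time of 7 days; a lower number here means that less compound is tolerated, a higher number that more compound is tolerated:

- compound 1 `CC(C)Nc1nc(N)nc2c1ncn2/C=C1/CC1(CO)CO`: > 24000 nM, a limit
- compound 2 `CCCNc1nc(N)nc2c1ncn2/C=C1/CC1(CO)CO`: > 24000 nM, a limit
- compound 3 `CC(C)CNc1nc(N)nc2c1ncn2/C=C1/CC1(CO)CO`: > 24000 nM, a limit

Compound 3 stands at > 24000 nM, which is a limit and not a number. The two other compounds stand at that same limit too: the limit of > 24000 nM in this assay, at which 3 of the 3 values shown sit.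

Compound 4 `Nc1nc(SC2CCCC2)c2ncn(/C=C3/CC3(CO)CO)c2n1` has cyclopentylsulfanyl in place of the isobutylamino of compound 3, on an aromatic carbon next to the ring nitrogen: cyclopentylsulfanyl in place of isobutylamino on an aromatic carbon.

The measured steps give little guidance. They are a step that the two limits leave unreadable from compound 1 to compound 2, a step that the two limits leave unreadable from compound 1 to compound 3 and a step that the two limits leave unreadable from compound 2 to compound 3. All three exchange one alkyl group on the nitrogen for another, and none has a readable size. Going by the values given here, no measured compound carries a sulfur-linked group or lacks the amino link at this carbon, so no measured step covers this change.

In this assay, no step beyond the scatter is therefore expected, although a fall cannot be excluded. The reference point is compound 3 at > 24000 nM, and this keeps the expectation close to that limit, with the wider margin on the lower side.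

The expected change is a number no higher from compound 3 to compound 4 (the limit leaves the size open).

For compound 4 the estimate is 24000 nM, with an expected range from 7000 nM to 60000 nM.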

Compound 4, half-maximal cytotoxic concentration: > 20000 nM
Compound 4 ended at the assay's limit; the forecaster's own chance of this, stated with the estimate: 60%; the middle value lies beyond the limit too.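

In this assay, going by these compounds alone, compound 4 gives > 20000 nM, a limit and not a number, and no step to compound 4 from compound 1, compound 2 or compound 3 can be read. The compounds shown leave open whether cyclopentylsulfanyl in place of isopropylamino, propylamino or isobutylamino changes the half-maximal cytotoxic concentration at all, and by how much.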